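Cinnamamide benzophenones: nitro for fluoro on the aryl

The source may report more compounds than this note shows. Statements on the series, on what has been measured and on what is new or still open speak of the compounds shown alone.

Compound 1 `COc1cccc(/C=C/C(=O)Nc2cc(C(=O)c3cc(OC)c(OC)c(OC)c3)ccc2OC)c1` and compound 2 `COc1ccc(C(=O)c2cc(OC)c(OC)c(OC)c2)cc1NC(=O)/C=C/c1ccc(F)cc1` share the benzophenone cinnamamide core and differ only in the aryl group on the double-bonded chain. Among the compounds with values here, in a functional assay on ME-180 cells (Homo sapiens) for cytotoxicity, read by MTT assay, with a stated time of 72 h (a higher number here means a weaker inhibitor, a lower number a stronger inhibitor), compound 1 gives 4300 nM, while compound 2 gives 300 nM; the step of a 14-fold lower number from compound 1 to compound 2 (1.16 log units; beyond the scatter) is the only measured step in the set. Compound 2 therefore holds the lowest number among the two measured compounds, with compound 1 the nearest and far behind.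

Compound 3 `COc1ccc(C(=O)c2cc(OC)c(OC)c(OC)c2)cc1NC(=O)/C=C/c1ccc([N+](=O)[O-])cc1` keeps the core of compound 2 and carries the change (nitro in place of fluoro on an aromatic carbon). Within the data shown here, the step from compound 1 to compound 2 is the only one bearing on this change, and it shows that swapping the aryl substituent can move the number strongly; it does not, however, show how a nitro group behaves. Compound 3 is expected to stay near compound 2 with a modest step of a 1.7-fold higher number from compound 2 to compound 3 (0.22 log units; within the scatter), estimated at 500 nM within 150 nM to 2000 nM.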

Compound 3, half-maximal inhibitory concentration: 9300 nM
The estimate for compound 3 lay 19-fold (1.27 log units) below the measured number, and the stated range ends below it.
By their numbers in this assay, from the lowest: compound 2; then compound 1; then compound 3.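

In this assay the exchange of 4-fluorophenyl for 4-nitrophenyl on the shared core is far from neutral, with a 31-fold higher number from compound 2 to compound 3 (1.49 log units; beyond the scatter) on the change of this single substituent. Within the data shown here, the earlier step showed only that one aryl exchange could lower the number; this one shows that a change confined to the substituent para to a large group can raise it by a similarly large margin. The 4-nitrophenyl group also falls behind 3-methoxyphenyl, with a 2.2-fold higher number from compound 1 to compound 3 (0.34 log units; beyond the scatter) as a modest step, so the three aryl groups give no simple order around a single substituent type.

It remains open whether an amine, a nitrile or a trifluoromethyl group at this place would stay close to fluoro or to nitro, and the compounds shown do not separate the effect of the substituent's place from that of its identity. No measurement at hand bears on the size of the step to the nitro compound.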